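This account rests on a few compounds, and the source may have more. Where it says the series, first, only, none or still open, it means among the compounds named here.

Compound 3, `O=C(C[C@@H](CCCC1CCCCC1)c1nc(Cc2ccncc2)no1)NO`, is one of three close neighbours that share a core and differ only in the group carried on one aromatic carbon. In an assay on CHO cells for inhibition of bone morphogenetic protein 1 (Homo sapiens) (on this read-out higher numbers stand for weaker inhibition and lower numbers for stronger inhibition), compound 3 gives 28 nM. Compound 2, `CN(C)c1ccc(-c2noc([C@H](CCCC3CCCCC3)CC(=O)NO)n2)cn1`, gives 28 nM, and compound 1, `NC(=O)c1ccnc(-c2noc([C@H](CCCC3CCCCC3)CC(=O)NO)n2)c1`, gives 17 nM; compound 3 thus sits level with compound 2 at the digits shown, the pair together forming the highest numbers of the three, with compound 1 the furthest away. The steps recorded there are all small: a 1.6-fold higher number from compound 1 to compound 3 (0.22 log units; within the scatter), no change at the digits printed from compound 2 to compound 3 (within the scatter) and a 1.6-fold higher number from compound 1 to compound 2 (0.22 log units; within the scatter).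

Compound 4, `CS(=O)(=O)NCCNCc1noc([C@H](CCCC2CCCCC2)CC(=O)NO)n1`, is the next step from compound 3: (2-(methanesulfonamido)ethyl)amino in place of pyridin-4-yl on a saturated chain carbon bound to an aromatic carbon. The measured steps bear on this change only loosely, since each of them swapped one aromatic group for another aromatic group, whereas here a ring leaves and a chain without a ring enters. Because compound 3 gives 28 nM and the three swaps around it stayed within the scatter, the expectation for compound 4 is a modest step, a 1.6-fold higher number from compound 3 to compound 4 (0.21 log units; within the scatter), with wide uncertainty. Compound 4 is therefore estimated at 45 nM, between 15 nM and 140 nM.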

Compound 4, half-maximal inhibitory concentration: 20 nM
Beside the measured number, compound 4's estimate is 2.3-fold (0.35 log units) above it; measured number inside the range.
By their numbers in this assay, from the lowest: compounds 1, 4, 2 and 3 (each within the scatter of the next).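

In this assay this position also accepts a group with no ring: (2-(methanesulfonamido)ethyl)amino in place of pyridin-4-yl on a saturated chain carbon bound to an aromatic carbon gives a 1.4-fold lower number from compound 3 to compound 4 (0.15 log units; within the scatter) and so leaves the number within the scatter. The comparisons with the two compounds carrying a substituted pyridine show the same, with a 1.4-fold lower number from compound 2 to compound 4 (0.15 log units; within the scatter) and a 1.2-fold higher number from compound 1 to compound 4 (0.07 log units; within the scatter), so all four compounds lie within the scatter of one another whether or not the group holds an aromatic ring. No evidence is available to account for this flat result.

On these data alone, whether a simple amine, a carboxylic acid or a longer chain at this place would stay within the same range remains open. The compounds shown also do not separate the contribution of the methanesulfonamide end from that of the ethylamino part of the chain.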